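A few compounds are considered here, and "the series" means these few. Any claim that something is new, unique, unknown or untested is made for them only; others in the source may bear on it.

Series notes, metabolic stability.

Compound 1 `CCCCCCCCc1ccc(OCC(=O)Cn2nnc(-c3ccccc3)n2)cc1` is the parent; in an ADME assay on S9 fraction from liver (Rattus norvegicus) for metabolic stability, read by LC-MS, using NADPH, with a stated time of 30 min (on this read-out higher numbers stand for a more stable compound and lower numbers for a less stable compound), compound 1 gives 33%. Among the numbers given outright it is the lower of the two: compound 2 `CCCCCCCCc1ccc(OCC(=O)Cn2nnc(-c3ccc(Cl)cc3)n2)cc1` gives 74%, and the step of a number 41 percentage points higher from compound 1 to compound 2 (beyond the scatter) is the only one so far that raises the read-out. Compound 3 `CCCCCCCCc1ccc(OCC(=O)Cn2nnc(CCC(=O)O)n2)cc1` is a separate case; in this assay compound 3 gives < 5%, which is a limit of the assay, not a number (the limit of < 5% in this assay, at which 1 of the 3 values shown sits). The steps of a number at least 28 percentage points lower from compound 1 to compound 3 (beyond the scatter) and a number at least 69 percentage points lower from compound 2 to compound 3 (beyond the scatter) both fall away from the measured pair, as far as the limit allows them to be counted.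

Compound 4 `CCCCCCCCc1ccc(OCC(=O)Cn2nnc(-c3ccc(C(=O)O)cc3)n2)cc1` differs from compound 1 by carboxy in place of hydrogen on an aromatic carbon. Two of the measured steps touch this change: compound 1 to compound 2 puts a group at the same place on the same ring and was large upward, while compound 1 to compound 3 brings a carboxylic acid onto the core and was at least modest downward. Compound 4 carries both features at once, so the two pulls are expected roughly to offset, with the acid keeping the number from climbing far; the expected step is a number 3 percentage points lower from compound 1 to compound 4 (within the scatter), within or only slightly beyond the scatter. The estimate for compound 4 in this assay is 30%, expected to lie between 8% and 62%.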

Compound 4, percent of the compound remaining: < 5%
Compound 4: no number, only a limit (the forecaster's own chance of this, stated with the estimate: 10%); at least 25 percentage points between middle value and limit.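

In this assay compound 4 gives < 5%, which is a limit of the assay and not a number: the limit of < 5% in this assay, at which 2 of the 4 values shown sit.

The position para to a large group on the phenyl ring therefore does not raise the read-out whatever group is placed there: carboxy in place of hydrogen gives a number at least 28 percentage points lower from compound 1 to compound 4 (beyond the scatter), and carboxy in place of chloro gives a number at least 69 percentage points lower from compound 2 to compound 4 (beyond the scatter), so the gain seen with chloro does not carry over to carboxy. Compound 3 and compound 4 both sit at the limit, so keeping the phenyl ring and carrying the carboxylic acid on it gives no readable advantage over the 2-carboxyethyl group, and the step between these two compounds cannot be read.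

The compounds shown leave open whether a methyl ester or a primary amide at the same place would stay near compound 2 or fall to the limit with compound 4. From the compounds shown here alone, it also remains open whether fluoro or methyl at this position would raise the read-out as chloro does, or whether that gain belongs to chloro alone.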